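The compounds below may be only part of what the source reports. "The series", "measured", "known", "first", "only" and "open" are said of these compounds alone.

Measured compounds:
compound 1 `COc1nc(C2=NOCC(c3ccc(C)cc3)N2)ccc1-n1cnc(C)c1` gives 135 mL/min/kg in an ADME assay on cells (Hepatocyte, Homo sapiens) for pharmacokinetics; on this read-out higher numbers stand for fast clearance and lower numbers for slow clearance
compound 2 `COc1nc(C2=NOCC(c3ccc(C)c(Cl)c3)N2)ccc1-n1cnc(C)c1` gives 422 mL/min/kg in this assay
compound 3 `COc1nc(C2=NOC(C)(C)C(c3ccccc3)N2)ccc1-n1cnc(C)c1` gives 5 mL/min/kg in this assay

Compound 4 `COc1nc(C2=NOC(C)(C)C(c3ccc(Cl)cc3)N2)ccc1-n1cnc(C)c1` is not yet measured in this assay.

The difference between the core of compound 1 and the core of compound 3 is not broken down here; compound 3 gives the lowest number of the three, a gap from compound 1 that lies beyond the scatter.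

From compound 1 to compound 2 the change is chloro in place of hydrogen on an aromatic carbon, and it made the step of a 3.1-fold higher number from compound 1 to compound 2 (0.49 log units; beyond the scatter). From compound 3 to compound 4 the change is chloro in place of hydrogen on an aromatic carbon. It is the same kind of change, not the same: in compound 2 the chloro sits ortho to a methyl group and meta to a large group, in compound 4 para to a large group, on a ring that carries no methyl.

For the measured compounds named here, with only one earlier step to rest on, compound 4 is expected to show a step of a 2.6-fold higher number from compound 3 to compound 4 (0.41 log units; beyond the scatter) in this assay, of about the size seen because of a 3.1-fold higher number from compound 1 to compound 2 (0.49 log units; beyond the scatter). Compound 4 is estimated at 13 mL/min/kg, within 5 mL/min/kg to 35 mL/min/kg.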

Compound 4, clearance: 15 mL/min/kg
Beside the measured number, compound 4's estimate is 1.2-fold (0.06 log units) below it; the range from low to high includes it.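

In this assay, chloro in place of hydrogen on an aromatic carbon gives a 3.0-fold higher number from compound 3 to compound 4 (0.48 log units; beyond the scatter). Set beside the earlier step, the change carries from one core to the other at much the same size: the same change on two cores in this assay, a 3.1-fold higher number (0.49 log units; beyond the scatter) from compound 1 to compound 2 and a 3.0-fold higher number (0.48 log units; beyond the scatter) from compound 3 to compound 4, 1.0-fold (0.02 log units) apart, within the scatter of two such steps. For the compounds shown here, this rests on only two pairs, with the chloro para to a large group in compound 4 and in a different place on a methyl-bearing ring in compound 2, so it shows neither that the step would hold on a further core or at another ring place, nor what lies behind it.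

The compounds shown leave open whether fluoro, a nitrile or an amine in place of that chloro would move the clearance number in the same way. They also leave open how the gap between the core of compound 1 and the core of compound 3 divides among the places where the two differ, as no pair shown changes one of those places alone.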